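Acylguanidine series: ring to ethylsulfanyl swap

The compounds below may be only part of what the source reports. "The series", "measured", "known", "first", "only" and "open" are said of these compounds alone.

Measured so far:
compound 1 `Cc1cc(C2CCCCC2)c(S(C)(=O)=O)cc1C(=O)N=C(N)N` — 22 nM
compound 2 `Cc1cc(-c2ccccc2)c(S(C)(=O)=O)cc1C(=O)N=C(N)N` — 19 nM

In a functional assay for inhibition of sodium/hydrogen exchanger (Oryctolagus cuniculus) (a higher number here means a weaker inhibitor, a lower number a stronger inhibitor), compound 2 stands at the lower of the two numbers, with compound 1 nearest; the step of a 1.2-fold lower number from compound 1 to compound 2 (0.06 log units; within the scatter) is within the scatter, so the two compounds cannot be told apart on these data. Exchanging the saturated ring for an aromatic one thus left the read-out essentially unchanged.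

Compound 3 `CCSc1cc(C)c(C(=O)N=C(N)N)cc1S(C)(=O)=O` has not yet been measured in this assay. It differs from compound 2 by ethylsulfanyl in place of phenyl on an aromatic carbon. Going by the values given here, no measured step covers this kind of change: the only step available, from compound 1 to compound 2, swaps one six-membered ring for another and is within the scatter, so it gives no guide to removing the ring altogether. The expectation therefore rests on little; a moderate loss is taken as the more likely outcome, but a result within the scatter of compound 2 cannot be excluded.

For compound 3 a value of 50 nM is expected, with a range of 15 nM to 200 nM. This corresponds to an expected step of a 2.6-fold higher number from compound 2 to compound 3 (0.42 log units; beyond the scatter).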

Compound 3, half-maximal inhibitory concentration: 5.9 nM
Estimate against measurement, compound 3: 8.5-fold (0.93 log units) above; the measured number lies below the stated range.
By their numbers in this assay, from the lowest: compound 3; then compounds 2 and 1 (each within the scatter of the next).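

In this assay, the aromatic carbon ortho to a methylsulfonyl group does not need to carry a six-membered ring: ethylsulfanyl, with no ring and 3 heavy atoms, gives a 3.2-fold lower number from compound 2 to compound 3 (0.51 log units; beyond the scatter) and, against the saturated ring, a 3.7-fold lower number from compound 1 to compound 3 (0.57 log units; beyond the scatter). The earlier pair showed only that phenyl and cyclohexyl could not be told apart, whereas both of these steps lie beyond the scatter, so the read-out at this position does respond to the group placed there, and among the three compounds the open-chain group gives the lowest number. Nothing available bears on why the number falls with this change.

With ethylsulfanyl the only open-chain group shown, the compounds do not separate the contribution of the sulfur atom from that of the short chain or the absence of a ring, and the pattern cannot be extended beyond these three compounds. An ethoxy group or a propyl chain at the same carbon would bear on the first question, and a longer alkylsulfanyl chain such as butylsulfanyl would show how far the chain can grow.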